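The source may report more compounds than this note shows. Statements on the series, on what has been measured and on what is new or still open speak of the compounds shown alone.

Compound 1 `COc1cc(/C=C/C(=O)Nc2ccccc2N)ccc1OCC(=O)Nc1cccc(F)c1` reaches in a functional assay on MCF7 cells (Homo sapiens) for inhibition, read by MTT assay, with a stated time of 48 h (a higher number here means a weaker inhibitor, a lower number a stronger inhibitor), only the limit > 100000 nM and no number. Compound 2 `COc1cc(/C=C/C(=O)Nc2ccccc2N)ccc1OCC(=O)Nc1ccc(Cl)c(Cl)c1` likewise returns only the limit > 100000 nM in this assay. Among the measured compounds shown here, the single measured step, a step that the two limits leave unreadable from compound 1 to compound 2, cannot be read, both values sitting at the limit of > 100000 nM in this assay, at which 2 of the 2 values shown sit. Compound 3 `COc1ccc(NC(=O)COc2ccc(/C=C/C(=O)Nc3ccccc3N)cc2OC)cc1` differs from compound 2 by 4-methoxyphenyl in place of 3,4-dichlorophenyl on an amide-type nitrogen. No readable step bears on this change, and with compound 2 at its limit there is no number to move from. Compound 3 is expected to stay near the limit, estimated at 150000 nM within 40000 nM to 600000 nM. The step that the limit leaves unreadable from compound 2 to compound 3 that this estimate means is expected to be none beyond the scatter.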

Compound 3, half-maximal inhibitory concentration: > 100000 nM
Compound 3 gave a limit, no number; the forecaster's own chance of this, stated with the estimate: 75%; the middle value lies beyond the limit too.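

No step can be read among compound 1, compound 2 and compound 3, since all three values are limits and not numbers: the limit of > 100000 nM in this assay, at which 3 of the 3 values shown sit. In this assay the compounds shown leave open whether any group on the amide-type nitrogen gives a readable value.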